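Isobutyl to phenyl: working notes on compound 4

The source may hold more compounds than are shown below. What is called first, only, known or untested is meant among the compounds shown, and "the series" means these compounds.

Among the compounds with values here, in a functional assay on NCI-H460 cells (Homo sapiens) for antiproliferative activity, read by MTT assay, with a stated time of 48 h (on this read-out lower numbers stand for stronger inhibition and higher numbers for weaker inhibition), compound 3 (`Cc1ccc(Nc2ccc3c(c2)C(O)(CCC(C)C)C(=O)N3)cc1`) gives 22700 nM, the only true number so far. Compound 2 (`CCCCCC1(O)C(=O)Nc2ccc(Nc3ccc(C)cc3)cc21`) reads > 100000 nM, which is a limit of the assay and not a number.

The next structure is compound 4 (`Cc1ccc(Nc2ccc3c(c2)C(O)(Cc2ccccc2)C(=O)N3)cc1`). The change is phenyl in place of isobutyl on a saturated chain carbon bound to a saturated ring carbon, which also reads as isopentyl to benzyl. Compound 1 (`COc1ccc(Nc2ccc3c(c2)C(O)(Cc2ccccc2)C(=O)N3)cc1`), which carries the same benzyl, reads > 100000 nM, again a limit of the assay and not a number.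

Within the data shown here, one measured step touches this chain: an at least 4.4-fold lower number from compound 2 to compound 3 (0.64 log units; beyond the scatter). Its size shows that this assay can respond to a small edit at this place, so a step of similar modest size is expected here. The direction expected is toward a higher number, given that compound 1 shows > 100000 nM with the benzyl in place. The expected step is a 2.2-fold higher number from compound 3 to compound 4 (0.34 log units; beyond the scatter). For compound 4 the estimated value is 50000 nM, with an expected range of 15000 nM to 100000 nM.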

Compound 4, half-maximal inhibitory concentration: 31600 nM
For compound 4 the middle estimate is 1.6-fold (0.20 log units) above the measured one, within the range that was stated.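

In this assay the phenyl in place of isobutyl leaves compound 3 and compound 4 within the scatter of each other, a 1.4-fold higher number from compound 3 to compound 4 (0.14 log units; within the scatter), so isopentyl and benzyl read alike at this place on the shared core. Phenyl in place of butyl gives an at least 3.1-fold lower number from compound 2 to compound 4 (0.50 log units; beyond the scatter), and methyl in place of methoxy on an aromatic carbon gives an at least 3.1-fold lower number from compound 1 to compound 4 (0.50 log units; beyond the scatter), so with the benzyl held constant, the aromatic substituent alone separates compound 1 from compound 4. Both of these steps start from a limit of the assay, not a number, and give only a minimum size: the limit of > 100000 nM in this assay, at which 2 of the 4 values shown sit.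

From the compounds shown here alone, what an amine or a carboxylic acid on this chain would do in this assay remains open. So does the effect of a longer chain carrying the phenyl.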